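The source may report more compounds than this note shows. Statements on the series, on what has been measured and on what is new or still open speak of the compounds shown alone.

Compound 1: `Cc1ccc(-c2cc(NC(=O)/C=C/c3ccc(C(F)(F)F)cc3)n[nH]2)cc1`, 720 nM
Compound 2: `O=C(/C=C/c1ccccc1)Nc1cc(-c2ccc(Br)cc2)[nH]n1`, 1120 nM

Both numbers come from a functional assay on MCF7 cells (Homo sapiens) for antiproliferative activity, read by MTT assay, with a stated time of 48 h; a higher number here means a weaker inhibitor, a lower number a stronger inhibitor. They lie within the usual scatter of repeated measurements, so these data do not separate compound 1 from compound 2. Among the measured compounds shown here, compound 1 therefore stands level with the only other measured compound, and neither can be called the better one.

Compound 3 `Cc1ccc(-c2cc(NC(=O)/C=C/c3ccc(Br)cc3)n[nH]2)cc1` keeps the core of compound 1 and makes a single change: bromo in place of trifluoromethyl on an aromatic carbon, para to a large group (bromo in place of trifluoromethyl on an aromatic carbon). For the measured compounds named here, no measured pair shows this swap on its own, so its effect in this assay has not been observed directly. The nearest hint is that compound 2 also carries a bromo group, and compound 2 gives 1120 nM, a value within the scatter of compound 1. A change beyond the scatter is therefore not expected, though a slightly higher number is possible. The expected 1.3-fold higher number from compound 1 to compound 3 (0.10 log units; within the scatter) is small. For compound 3, the estimated value is 900 nM, with an expected range from 350 nM to 2300 nM.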

Compound 3, half-maximal inhibitory concentration: 1370 nM
Estimate against measurement, compound 3: 1.5-fold (0.18 log units) below, within the range that was stated.
By their numbers in this assay, from the lowest: compounds 1, 2 and 3 (each within the scatter of the next).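

In this assay, among the compounds shown here, compound 1 and compound 3 form the first pair that differs in one place only, so the swap of trifluoromethyl for bromo on an aromatic carbon, para to a large group, can now be read directly: a 1.9-fold higher number from compound 1 to compound 3 (0.28 log units; within the scatter). Although a group of four heavy atoms gives way to a single bromine atom, this assay does not separate the two compounds, so at this position, and on the core of compound 1, either group fits the same level of antiproliferative activity as far as these data can tell. No independent measurement is available to explain this result.

This one pair cannot show whether the position matters in general, since both groups sit on the same core and were compared in a single cell line. An amine, a carboxylic acid or a longer alkyl chain at this position could show whether a very different group moves the number beyond the scatter, and the same swap on another core could test whether the result carries over.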